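The compounds below may be only part of what the source reports. "The series", "measured", "known", "first", "only" and "open" are said of these compounds alone.

Measured so far:
compound 1 `COc1cc2[nH]c(=O)[nH]c2cc1NS(=O)(=O)c1cccc(Cl)c1Cl`, 316 nM
compound 2 `COc1cc2c(cc1NS(=O)(=O)c1cccc(Cl)c1Cl)[nH]c(=O)n2C1CNC1`, 398 nM

In a functional assay on CHO cells for antagonist activity at C-C chemokine receptor type 4 (Homo sapiens), read by radioligand binding and GTPgammaS binding (on this read-out lower numbers stand for stronger inhibition and higher numbers for weaker inhibition), compound 1 holds the lower of the two numbers; compound 2 lies nearest, and the step of a 1.3-fold higher number from compound 1 to compound 2 (0.10 log units; within the scatter) stays within the scatter. Compound 3 `COc1cc2[nH]c(=O)n(C)c2cc1NS(=O)(=O)c1cccc(Cl)c1Cl` differs from compound 1 by methyl in place of hydrogen on an aromatic nitrogen. Among the compounds with values here, the only measured step that bears on this change is the substitution on an aromatic nitrogen from compound 1 to compound 2, which gave no shift beyond the scatter. No shift beyond the scatter is therefore expected for compound 3, an estimated step of a 1.1-fold higher number from compound 1 to compound 3 (0.04 log units; within the scatter). Compound 3 is expected at 350 nM, within 150 nM to 800 nM in this assay.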

Compound 3, half-maximal inhibitory concentration: 20000 nM
Estimate against measurement, compound 3: 57-fold (1.76 log units) below, outside the stated range (above it).
By their numbers in this assay, from the lowest: compounds 1 and 2 (each within the scatter of the next); then compound 3.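

In this assay, the two ring nitrogens of the shared core do not behave alike: methyl on the nitrogen substituted in compound 3 gives a 63-fold higher number from compound 1 to compound 3 (1.80 log units; beyond the scatter), whereas azetidin-3-yl on the other ring nitrogen gives a 1.3-fold higher number from compound 1 to compound 2 (0.10 log units; within the scatter). Tolerance of a substituent at one nitrogen therefore does not carry over to the other, and a single added carbon is enough for a large loss at this one. Nothing at hand accounts for this loss.

Still open, as far as these compounds go, is whether a longer chain such as ethyl, or a chain bearing an amine, behaves like methyl at this nitrogen. Methyl on the other ring nitrogen would show whether that nitrogen tolerates the same small group.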